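The source may hold more compounds than are shown below. What is called first, only, known or untested is meant among the compounds shown, and "the series" means these compounds.

Values in a functional assay on MCF7 cells (Homo sapiens) for inhibition, read by MTT assay, with a stated time of 48 h; a higher number here means a weaker inhibitor, a lower number a stronger inhibitor:
Compound 1 `CCNC(=O)/C=C/c1c(/C=C/c2ccc(OC)cc2)cc(OC)cc1OC`: 7060 nM
Compound 2 `CCCCCCNC(=O)/C=C/c1c(/C=C/c2ccc(OC)cc2)cc(OC)cc1OC`: 5530 nM
Compound 3 `COc1ccc(/C=C/c2cc(OC)cc(OC)c2/C=C/C(=O)N2CCCC(C)C2)cc1`: 11900 nM

Compound 3 stands level with compound 1 within the scatter and apart from compound 2 by a modest margin. Compound 4 `COc1ccc(/C=C/c2cc(OC)cc(OC)c2/C=C/C(=O)N2CCN(C)CC2)cc1` has 4-methylpiperazin-1-yl in place of 3-methylpiperidin-1-yl on a carbonyl carbon. Going by the values given here, no measured step makes this exact exchange. The closest evidence is the two exchanges on that carbonyl carbon, a 1.7-fold higher number from compound 1 to compound 3 (0.23 log units; within the scatter) and a 2.2-fold higher number from compound 2 to compound 3 (0.33 log units; beyond the scatter). Lengthening the chain gave a 1.3-fold lower number from compound 1 to compound 2 (0.11 log units; within the scatter). All three steps are small, so no change beyond the scatter is expected in this assay. The expected step is a 1.2-fold lower number from compound 3 to compound 4 (0.08 log units; within the scatter). Compound 4 is estimated at 10000 nM, with an expected range from 4500 nM to 22000 nM.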

Compound 4, half-maximal inhibitory concentration: 2290 nM
Estimate against measurement, compound 4: 4.4-fold (0.64 log units) above, outside the stated range (below it).
By their numbers in this assay, from the lowest: compound 4; then compounds 2, 1 and 3 (each within the scatter of the next, the first and the last beyond it).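

In this assay, compound 4 has the lowest number of the set, and the group on the carbonyl carbon now moves the result beyond the scatter against every earlier compound: a 5.2-fold lower number from compound 3 to compound 4 (0.72 log units; beyond the scatter) and a 2.4-fold lower number from compound 2 to compound 4 (0.38 log units; beyond the scatter) and a 3.1-fold lower number from compound 1 to compound 4 (0.49 log units; beyond the scatter). The ring size and heavy-atom count stay the same, while a second ring nitrogen and a hydrogen-bond acceptor enter. Nothing available explains this gain. The second nitrogen and the changed methyl place enter together, so their shares remain unseparated. Morpholin-4-yl or unsubstituted piperazin-1-yl on that carbonyl carbon would bear on this question.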